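This account rests on a few compounds, and the source may have more. Where it says the series, first, only, none or still open, it means among the compounds named here.

Among the measured compounds shown here, compound 2 `CCNC(=O)NCCCc1cccc2c1C[C@@H](CCCCc1ccccc1)O2` gives the higher of the two numbers measured so far: in an assay on NIH3T3 cells for binding affinity to melatonin receptor type 1A (Homo sapiens) (on this read-out lower numbers stand for stronger inhibition and higher numbers for weaker inhibition), compound 2 gives 9 nM, whereas compound 1 `CCC(=O)NCCCc1cccc2c1C[C@@H](CCCCc1ccccc1)O2` gives 1 nM. For the measured compounds named here, the one measured step, a 9.0-fold higher number from compound 1 to compound 2 (0.95 log units; beyond the scatter), records what happened when an ethyl on the carbonyl carbon gave way to ethylamino. Compound 3 `CC(C)C(=O)NCCCc1cccc2c1C[C@@H](CCCCc1ccccc1)O2` is the next member. It differs from compound 2 in one place: isopropyl in place of ethylamino on a carbonyl carbon. Going by the values given here, the carbonyl carbon thus again carries an alkyl group rather than an amino group, as in compound 1, though the alkyl is now isopropyl and no measured pair shows what branching does at this position. The expected step is a 4.5-fold lower number from compound 2 to compound 3 (0.65 log units; beyond the scatter), a reversal of most of a 9.0-fold higher number from compound 1 to compound 2 (0.95 log units; beyond the scatter), with some allowance for the unknown effect of isopropyl. Compound 3 is therefore expected to give 2 nM, within a range from 0.6 nM to 7 nM.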

Compound 3, inhibition constant: 4 nM
Beside the measured number, compound 3's estimate is 2.0-fold (0.30 log units) below it; the range from low to high includes it.
By their numbers in this assay, from the lowest: compound 1; then compound 3; then compound 2.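

In this assay the step of a 2.3-fold lower number from compound 2 to compound 3 (0.35 log units; beyond the scatter) shows that the lower number on leaving ethylamino is not tied to the ethyl of compound 1, since isopropyl on the carbonyl carbon also gives one. The step of a 4.0-fold higher number from compound 1 to compound 3 (0.60 log units; beyond the scatter) gives the first measured effect of branching here: methyl in place of hydrogen on the chain carbon bound to the carbonyl carbon raises the number beyond the scatter. No supporting data on the reason for either step are available.

The compounds shown leave open how a smaller methyl, a longer propyl chain or a more branched tert-butyl group on the carbonyl carbon would compare with ethyl and isopropyl. They also leave open whether a cyclopropyl ring would behave like isopropyl at this position.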